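Benzoxazole substituent swap, fluoro to methyl, in the HT-29 series

The compounds below may be only part of what the source reports. "The series", "measured", "known", "first", "only" and "open" are said of these compounds alone.

Three compounds of the shared core have numbers in a functional assay on HT-29 cells (Homo sapiens) for cytotoxicity, read by MTT assay, with a stated time of 24 h; a higher number here means a weaker inhibitor, a lower number a stronger inhibitor. Compound 1 `CN(C)CCN1CCN(CC(=O)Nc2ccc(-c3nc4cc(F)ccc4o3)cc2)CC1` gives 8190 nM. Compound 2 `Cc1cc(-c2nc3cc(F)ccc3o2)ccc1NC(=O)CN1CCN(CCN(C)C)CC1` gives 6600 nM; compound 3 `CN(C)CCCN1CCN(CC(=O)Nc2ccc(-c3nc4ccccc4o3)cc2)CC1` gives 10600 nM. Going by the values given here, compound 2 has the lowest of the three numbers, yet it stands within the scatter of both others, and the one single-point step measured, a 1.2-fold lower number from compound 1 to compound 2 (0.09 log units; within the scatter), is a change of methyl in place of hydrogen on an aromatic carbon. Compound 3 differs from compound 1 in more than one place, so its value is given as it is, without a step.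

Compound 4 `Cc1ccc2oc(-c3ccc(NC(=O)CN4CCN(CCN(C)C)CC4)c(C)c3)nc2c1` is not yet measured. It differs from compound 2 by methyl in place of fluoro on an aromatic carbon, the benzoxazole part reading 5-fluoro-1,3-benzoxazol-2-yl to 5-methyl-1,3-benzoxazol-2-yl. Among the compounds with values here, no measured step touches this position, and the only measured step, a 1.2-fold lower number from compound 1 to compound 2 (0.09 log units; within the scatter), concerns a different ring and lies within the scatter. The series gives no ground to expect a step beyond the scatter in this assay in either direction. The expected step is therefore a 1.1-fold higher number from compound 2 to compound 4 (0.03 log units; within the scatter). Compound 4 is estimated at 7000 nM in this assay, with a range from 3000 nM to 16000 nM.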

Compound 4, half-maximal inhibitory concentration: 7240 nM
Beside the measured number, compound 4's estimate is 1.0-fold (0.01 log units) below it, within the range that was stated.
By their numbers in this assay, from the lowest: compounds 2, 4, 1 and 3 (each within the scatter of the next).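

In this assay, going by these compounds alone, the exchange of 5-fluoro-1,3-benzoxazol-2-yl for 5-methyl-1,3-benzoxazol-2-yl gives a 1.1-fold higher number from compound 2 to compound 4 (0.04 log units; within the scatter) and is the first reading at this position of the shared core. Fluoro leaves and methyl enters, one heavy atom for one heavy atom, and this swap on the six-membered aromatic ring of the fused system does not carry the number beyond the scatter. Read with a 1.2-fold lower number from compound 1 to compound 2 (0.09 log units; within the scatter) at a different place on the core, it means that both single-place steps now available stay within the scatter, so neither place has yet shown a measurable effect in this assay, and nothing at hand explains why this exchange stays so small.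

The compounds shown leave open whether a methoxy group, a trifluoromethyl group, an amine or a carboxylic acid at this position would give a step beyond the scatter. As far as these compounds go, it also remains open how plain hydrogen at this position compares with fluoro and methyl while the rest of compound 2 stays the same.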